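The source may hold more compounds than are shown below. What is called first, only, known or untested is meant among the compounds shown, and "the series" means these compounds.

Measured so far:
compound 1, `CC(=O)Nc1nc(OCc2ccccc2)c2ncn(C3O[C@H](O)[C@@H](O)[C@H]3O)c2n1`, 200 uM
compound 2, `Nc1nc(OCc2ccccc2)c2ncn(C3O[C@H](O)[C@@H](O)[C@H]3O)c2n1`, 244 uM

Both were tested in a functional assay on M4Beu cells for cytotoxicity against M4Beu cell line (Homo sapiens), in the presence of a further agent that is not named here; on this read-out higher numbers stand for an effect only at larger amounts of compound and lower numbers for an effect already at smaller amounts. Compound 1 gives the lower of the two numbers, but the gap to compound 2, a 1.2-fold higher number from compound 1 to compound 2 (0.09 log units; within the scatter), is within the scatter, so the two cannot be told apart. Compound 3, `CC(=O)Nc1nc(OCc2ccncc2)c2ncn(C3O[C@H](O)[C@@H](O)[C@H]3O)c2n1`, differs from compound 1 by pyridin-4-yl in place of phenyl on a saturated chain carbon bound to an oxygen on an aromatic ring. No measured step tries this exchange; the only step shown, from compound 1 to compound 2, alters a different part of the molecule and gives no guidance on it. With nothing pointing either way, compound 3 is expected to stay close to compound 1, a step of no change at the digits printed from compound 1 to compound 3 (within the scatter), giving an estimate of 200 uM with a range from 90 uM to 450 uM.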

Compound 3, concentration for half-maximal effect: 400 uM
For compound 3 the middle estimate is 2.0-fold (0.30 log units) below the measured one, within the range that was stated.
By their numbers in this assay, from the lowest: compounds 1, 2 and 3 (each within the scatter of the next).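

Putting pyridin-4-yl in place of phenyl on the saturated chain carbon bound to an oxygen on an aromatic ring gives a 2.0-fold higher number from compound 1 to compound 3 (0.30 log units; within the scatter) in this assay. Changing this group, with one ring carbon exchanged for nitrogen, therefore moves the number no further than repeat measurements would. No measurement offered here explains this result.

Still open, going by these compounds, is whether a cyclohexyl group, or a phenyl ring carrying an amine or a carboxylic acid, would move the number beyond the scatter. On these data alone, the same exchange on compound 2 also remains open.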